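Hydroxy added to the linker chain of compound 2

A few compounds are considered here, and "the series" means these few. Any claim that something is new, unique, unknown or untested is made for them only; others in the source may bear on it.

Compound 2 `CO/N=C(/CCN1CCN(c2ccccn2)CC1)c1ccc(Cl)cc1` gives 56.6 nM in a functional assay on HEK293 cells with D(4) dopamine receptor (Homo sapiens) as the target, read by FLIPR (a lower number here means that less compound is needed, a higher number that more compound is needed for the effect), and it stands within the scatter of both other measured compounds. Compound 1 `CO/N=C(/CCN1CCN(c2ccccn2)CC1)c1ccccc1Cl` gives 57.2 nM in this assay, and compound 3 `CO/N=C(/CCN1CCN(c2ccccn2)CC1C)c1ccc(Cl)cc1` gives 99 nM. The step of a 1.0-fold lower number from compound 1 to compound 2 (0.00 log units; within the scatter) moved the chlorine on the aryl ring, and the step of a 1.7-fold higher number from compound 2 to compound 3 (0.24 log units; within the scatter) placed a methyl on a saturated ring carbon; neither left the scatter. Compound 4 `CO/N=C(\c1ccc(Cl)cc1)C(O)CN1CCN(c2ccccn2)CC1` differs from compound 2 by hydroxy in place of hydrogen on a saturated chain carbon bound to a carbon with a double bond to nitrogen and a saturated chain carbon. For the measured compounds named here, no measured step touches this chain carbon, so the two known steps bear on it only indirectly, as signs that small changes at other places left this assay unmoved. Going by the values given here, the new group brings a hydrogen-bond donor and acceptor to a position that has no precedent here, so a modest rise in the number, near the edge of the scatter, is expected for compound 4, a 1.9-fold higher number from compound 2 to compound 4 (0.29 log units; within the scatter). The estimate for compound 4 in this assay is 110 nM, ranging from 35 nM to 350 nM.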

Compound 4, half-maximal effective concentration: 46 nM
The estimate for compound 4 lay 2.4-fold (0.38 log units) above the measured number; measured number inside the range.
By their numbers in this assay, from the lowest: compounds 4, 2, 1 and 3 (each within the scatter of the next, the first and the last beyond it).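

In this assay, for the compounds shown here, the step, a 1.2-fold lower number from compound 2 to compound 4 (0.09 log units; within the scatter), shows that this saturated chain carbon, which no earlier step had touched, accepts a hydroxy in place of hydrogen with the number staying within the scatter. Going by these compounds alone, the earlier steps concerned only the aryl ring and a saturated ring carbon, so this is the first reading at the chain itself, and the hydrogen-bond donor and acceptor that enter with the hydroxy leave the number where it was, within the scatter. No measurement at hand explains this result.

From the compounds shown here alone, whether an amine, a methoxy group or a carboxylic acid on this chain carbon would also stay within the scatter remains open. So does whether the hydroxy would behave the same way alongside the 2-chlorophenyl of compound 1 or the methyl of compound 3.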